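A few compounds are considered here, and "the series" means these few. Any claim that something is new, unique, unknown or untested is made for them only; others in the source may bear on it.

Compound 3, with the structure `CC/N=C(\S)NCCCCCCn1nc(-c2ccccc2)ccc1=O`, gives the lowest of the three numbers recorded so far: in a functional assay on the whole organism with Rattus norvegicus as the target, at a dose of 100 mg/kg (on this read-out lower numbers stand for less inhibition and higher numbers for more inhibition at the one dose given (going by the name of the read-out)), compound 3 gives -5.6%. Its nearest neighbour is compound 2, `N#CNC(=N)NCCCCCn1nc(-c2ccccc2)ccc1=O`, which in this assay gives 31%; furthest away is compound 1, `C/N=C(/NC#N)NCCCn1nc(-c2ccccc2)ccc1=O`, which in this assay gives 40.5%. Among the compounds with values here, the only large change seen is a number 36.6 percentage points lower from compound 2 to compound 3 (beyond the scatter), in which a group of 7 heavy atoms (4 carbon, 2 nitrogen, 1 sulfur; no ring) replaced a group of 6 heavy atoms (2 carbon, 4 nitrogen; no ring). By contrast, a number 9.5 percentage points lower from compound 1 to compound 2 (within the scatter), where one group of carbon and nitrogen atoms replaced a related one, changed little.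

Compound 4, `CN(C)/C(=N/CCCCn1nc(-c2ccccc2)ccc1=O)NC#N`, is the unmeasured compound. Relative to compound 3, the change is a group of 8 heavy atoms (4 carbon, 4 nitrogen; no ring) in place of a group of 8 heavy atoms (5 carbon, 2 nitrogen, 1 sulfur; no ring), on a saturated chain carbon, four bonds along the chain from an aromatic nitrogen. This undoes the kind of change seen in compound 2 to compound 3, bringing back a group built only of carbon and nitrogen, with a nitrile, like those in compound 1 and compound 2. Because a number 36.6 percentage points lower from compound 2 to compound 3 (beyond the scatter) was large and downward, compound 4 is expected to move back upward; the expected step is a number 39.6 percentage points higher from compound 3 to compound 4 (beyond the scatter). Compound 4 is therefore estimated to give 34% in this assay, within a range from 14% to 54%.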

Compound 4, a percentage reported as inhibition, in the whole organism at one dose (the size of the read-out at that dose, not a potency): 80.7%
For compound 4 the middle estimate is 46.7 percentage points below the measured one; the measured number lies above the stated range.
By their numbers in this assay, from the lowest: compound 3; then compounds 2 and 1 (each within the scatter of the next); then compound 4.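

Within the data shown here, the result shows that this place, on a saturated chain carbon, four bonds along the chain from an aromatic nitrogen, can carry far more of the read-out in this assay than the earlier compounds suggested: the group of 8 heavy atoms (4 carbon, 4 nitrogen) gives a number 86.3 percentage points higher from compound 3 to compound 4 (beyond the scatter), a rise well beyond merely reversing the earlier fall. Having a nitrile and only carbon and nitrogen in the group is not enough to explain this, as compound 1 and compound 2 also fit that description, yet the change still gives a number 49.7 percentage points higher from compound 2 to compound 4 (beyond the scatter). No measurement here explains why this change has so large an effect.

The compounds shown leave open how much of the rise belongs to the entering group and how much to the chain, since the groups and their chain positions vary together across this small set. A longer chain carrying the group of compound 4, or a simple amine or a carboxylic acid at the same place, would help to separate the two.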